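The source may report more compounds than this note shows. Statements on the series, on what has been measured and on what is new or still open speak of the compounds shown alone.

In an ADME assay on a cell-free system (plasma, Rattus norvegicus) for metabolic stability, read by LC-MS, with a stated time of 60 min, at 37 degrees C, tested at 50 uM (a higher number here means that more of the compound is left, a lower number that less of the compound is left), compound 1, `CC(C)C(=O)OCOC(=O)C1=C(S[C@@H]2CN[C@H](C(=O)Nc3cccc(C(=O)O)c3)C2)[C@H](C)[C@@H]2[C@@H]([C@@H](C)O)C(=O)N12`, gives 0%: nothing of it is found after the stated time. Compound 2, `CC(C)OC(=O)OCOC(=O)C1=C(S[C@@H]2CN[C@H](C(=O)Nc3cccc(C(=O)O)c3)C2)[C@H](C)[C@@H]2[C@@H]([C@@H](C)O)C(=O)N12`, carries an isopropoxy in place of the isopropyl on a carbonyl carbon, and in this assay compound 2 gives 0%. The step of no change at the digits printed from compound 1 to compound 2 (within the scatter) therefore shows no difference beyond the scatter, and compound 2 stands level with compound 1 on the numbers shown.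

Compound 3, `COC(=O)OCOC(=O)C1=C(S[C@@H]2CN[C@H](C(=O)Nc3cccc(C(=O)O)c3)C2)[C@H](C)[C@@H]2[C@@H]([C@@H](C)O)C(=O)N12`, differs from compound 2 by methyl in place of isopropyl on an oxygen next to a carbonyl group. For the measured compounds named here, only the step from compound 1 to compound 2 bears on this, and it was flat; both measured compounds lose the whole of the compound within the test period. With nothing pointing upward, compound 3 is expected to be no different, and the step of no change at the digits printed from compound 2 to compound 3 (within the scatter) is expected to stay within the scatter. Compound 3 is estimated at 0%, between 0% and 10%.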

Compound 3, percent of the compound remaining in the plasma assay: 0%
The estimate for compound 3 equals the measured number at the digits printed; the measured number falls inside the stated range.
By their numbers in the plasma assay, from the lowest: compounds 1, 2 and 3 (each within the scatter of the next).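

In the plasma assay the shorter end group brings no change at the digits printed from compound 2 to compound 3 (within the scatter), and the methoxy brings no change at the digits printed from compound 1 to compound 3 (within the scatter), so going down to methyl on an oxygen next to a carbonyl group leaves the reading where it was. In a physicochemical assay for metabolic stability, read by LC-MS, in phosphate buffer, with a stated time of 3 h, at pH 7.4, tested at 50 uM (on this read-out lower numbers stand for a less stable compound and higher numbers for a more stable compound), compound 2 gives > 95%, which is a limit of the assay and not a number. In the physicochemical assay compound 3 gives > 95%, also a limit, so the step between these two compounds cannot be read, and all that can be said is that both sit at the same limit: the limit of > 95% in the physicochemical assay, at which 2 of the 2 values shown sit.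

With all three compounds at one reading in the plasma assay, these values cannot separate the groups compared. On these data alone, whether an amine or a longer chain in place of the methoxy would leave any compound remaining in the plasma assay stays open.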